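Swapping a Hydroxyethoxy Arm for an Aminopropylamino Chain

The source may report more compounds than this note shows. Statements on the series, on what has been measured and on what is new or still open speak of the compounds shown alone.

Three measured compounds share a fused two-ring core bearing an amine. Compound 1 `C[C@H](Nc1ncnc2cnc(N(C)C)cc12)c1ccccc1` carries a branched amine with a phenyl group, compound 2 `CCCC(C)Nc1ncnc2cnc(N(C)C)cc12` a simple alkyl amine, and compound 3 `OCCOc1cc2c(NC3CCCCC3)ncnc2cn1` a cyclohexylamine together with a 2-hydroxyethoxy group. In a functional assay on CHO cells for antagonist activity at metabotropic glutamate receptor 1 (Rattus norvegicus), with a stated time of 5 min (a lower number here means a stronger inhibitor, a higher number a weaker inhibitor), compound 1 gives 1400 nM, compound 2 gives 858 nM, and compound 3 gives 177 nM. Compound 3 therefore has the lowest number of the three, and its gaps to compound 2 and to compound 1 both lie beyond the usual scatter of repeated measurements. Each of these compounds differs from the others in more than one place. No single change can be credited with any of these gaps.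

Compound 4 `NCCCNc1cc2c(NC3CCCCC3)ncnc2cn1` keeps the cyclohexylamine of compound 3 and alters one group: (3-aminopropyl)amino in place of 2-hydroxyethoxy on an aromatic carbon. Within the data shown here, no pair of measured compounds isolates an exchange of this kind, so its effect cannot be read from the data. The step from compound 3 to compound 4 is expected to be a 1.7-fold higher number from compound 3 to compound 4 (0.23 log units; within the scatter), without a clear direction beyond the scatter. For compound 4 the estimate in this assay is 300 nM, within a range from 80 nM to 1200 nM.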

Compound 4, inhibition constant: 200 nM
Estimate against measurement, compound 4: 1.5-fold (0.18 log units) above; the measured number falls inside the stated range.
By their numbers in this assay, from the lowest: compounds 3 and 4 (each within the scatter of the next); then compounds 2 and 1 (each within the scatter of the next).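

Among these compounds, compound 3 and compound 4 are the first pair here that differ in one place only, and in this assay the exchange gives a 1.1-fold higher number from compound 3 to compound 4 (0.05 log units; within the scatter), so this swap can be read directly for the first time. On this aromatic carbon next to the ring nitrogen, with the cyclohexylamine held constant, (3-aminopropyl)amino and 2-hydroxyethoxy cannot be told apart by this read-out, although the entering chain has 5 heavy atoms in place of 4, nitrogen in place of oxygen, and 2 hydrogen-bond donors in place of 1. No measurement shown here accounts for this match between the two chains.

The compounds shown leave open whether a methoxy group, a longer chain or a chain ending in a carboxylic acid on this same carbon would also stay within the scatter of compound 3. They also leave open whether the two chains would still match if a different amine, such as a cyclopentylamine, took the place of the cyclohexylamine.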